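This account rests on a few compounds, and the source may have more. Where it says the series, first, only, none or still open, it means among the compounds named here.

The measured compounds in a physicochemical assay for solubility, with a stated time of 18 h, at pH 7.4; on this read-out higher numbers stand for higher solubility and lower numbers for lower solubility:
compound 1, `CCC(CC)c1ccc2c(NCCCNCc3cc(F)ccc3OC)ccnc2c1`, gives 4200 nM
compound 2, `CCC(CC)c1ccc2c(NCCCNCc3ccco3)ccnc2c1`, gives 4200 nM
compound 3, `Fc1ccc(Cc2ccc3c(NCCCNCc4ccco4)ccnc3c2)c(Cl)c1`, gives 4200 nM

Compound 1 stands level with compounds 2 and 3 at the digits shown; its nearest neighbour in this assay is compound 2, and even the furthest, compound 3, reads the same within the scatter. Compound 4, `COc1ccc(F)cc1CNCCCNc1ccnc2cc(CC(C)C)ccc12`, has not yet been measured. It differs from compound 1 at one point: isobutyl in place of pentan-3-yl on an aromatic carbon. Two measured steps give some guidance. The step of no change at the digits printed from compound 2 to compound 3 (within the scatter) also exchanges pentan-3-yl for another group on an aromatic carbon of the shared core, and it left the solubility where it was. The step of no change at the digits printed from compound 1 to compound 2 (within the scatter) alters a different part of the molecule, on a saturated chain carbon bound to an amine nitrogen, and likewise produced no shift. Across all three compounds the read-out sits at one level whichever group is swapped, so exchanging one chain for another on the same aromatic carbon is expected to leave it there as well. For compound 4 the step of no change at the digits printed from compound 1 to compound 4 (within the scatter) is therefore expected to stay within the scatter. The estimated solubility of compound 4 is 4200 nM, with a range from 2000 nM to 8500 nM.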

Compound 4, solubility: 4200 nM
Beside the measured number, compound 4's estimate shows no gap at the digits printed; the measured number falls inside the stated range.
By their numbers in this assay, from the lowest: compounds 1, 2, 3 and 4 (each within the scatter of the next).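

In this assay exchanging pentan-3-yl for isobutyl on this aromatic carbon gives no change at the digits printed from compound 1 to compound 4 (within the scatter) and so adds a direct comparison of two open carbon chains, with 5 heavy atoms leaving and 4 entering. The earlier step at this carbon gave no change at the digits printed from compound 2 to compound 3 (within the scatter) but it was read on compounds carrying furan-2-yl, and it replaced the chain with 2-chloro-4-fluorobenzyl, a group that contains a ring. The new pair carries 5-fluoro-2-methoxyphenyl instead, so among these compounds the reading at this position stays the same with either of those two groups elsewhere on the molecule.

All four compounds share one printed value, so the compounds shown do not reveal what, if anything, would move this read-out, and whether a carboxylic acid, an amine or a much longer chain on the same aromatic carbon would give a different number stays open. No supporting measurement is available to say what lies behind this unchanging reading.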